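This account rests on a few compounds, and the source may have more. Where it says the series, first, only, none or still open, it means among the compounds named here.

Three compounds have numbers in a functional assay on A2780 cells (Homo sapiens) for antiproliferative activity, read by CellTiter-Glo, with a stated time of 4 days; on this read-out lower numbers stand for stronger inhibition and higher numbers for weaker inhibition. In this assay compound 1 `O=C(NCc1cccnc1)Nc1ccc(CN2C(=O)c3ccccc3C2=O)cc1` gives 100 nM. Compound 2 `CCC(=O)N[C@@H](C)c1ccc(NC(=O)NCc2cccnc2)cc1` gives 340 nM. Compound 3 `C[C@H](NC(=O)CC(F)(F)F)c1ccc(NC(=O)[C@H]2C[C@@H]2c2cccnc2)cc1` gives 5 nM, the lowest of the three and clearly beyond the scatter from both of the others. Compound 4 `C[C@H](NC(=O)c1ncccn1)c1ccc(NC(=O)[C@H]2C[C@@H]2c2cccnc2)cc1` differs from compound 3 in one place, with pyrimidin-2-yl in place of 2,2,2-trifluoroethyl on a carbonyl carbon. Among the compounds with values here, no two measured compounds differ in only one place, which leaves this swap without a direct precedent. In this assay the expected step of a 1.8-fold higher number from compound 3 to compound 4 (0.26 log units; within the scatter) is a small one towards a higher number, about the size of the scatter. For compound 4 the estimated value is 9 nM, with an expected range from 2.5 nM to 35 nM.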

Compound 4, half-maximal inhibitory concentration: 14 nM
For compound 4 the middle estimate is 1.6-fold (0.19 log units) below the measured one; measured number inside the range.
By their numbers in this assay, from the lowest: compound 3; then compound 4; then compound 1; then compound 2.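

Within the data shown here, replacing 2,2,2-trifluoroethyl with pyrimidin-2-yl on this carbonyl carbon gives a 2.8-fold higher number from compound 3 to compound 4 (0.45 log units; beyond the scatter) in this assay and is the first change in this set that can be read in one place. Compound 4 still gives 14 nM here, so this position can carry an aromatic ring as well as a short fluorinated chain. Nothing shown here explains the step. From the compounds shown here alone, whether a phenyl ring or a tert-butyl group on the same carbonyl carbon would give a number nearer compound 3 or compound 4 remains open.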